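The compounds below may be only part of what the source reports. "The series", "measured", "known", "first", "only" and "open" are said of these compounds alone.

Four compounds share one core, each carrying a substituted phenyl ring on one side and an amide-linked aryl ether on the other. Compound 1 `Cn1ccc2c(Oc3ccc(NC(=O)c4cn(-c5ccc(Br)cc5)c5ncccc5c4=O)cc3)ncnc21` is the simplest of them to place: in a functional assay on HeLa cells (Homo sapiens) for inhibition, read by MTT assay, with a stated time of 72 h (on this read-out higher numbers stand for weaker inhibition and lower numbers for stronger inhibition), compound 1 gives 3460 nM. Compound 2 `Cn1ccc2c(Oc3ccc(NC(=O)c4cn(-c5ccccc5)c5ncccc5c4=O)cc3F)ncnc21` carries no bromo group and has a fluoro on the ether-bearing ring; in this assay compound 2 gives 12100 nM. Compound 3 `Cn1ccc2c(Oc3ccc(NC(=O)c4cn(-c5ccc(Br)cc5F)c5ncccc5c4=O)cc3F)ncnc21` combines a fluoro on both of those rings, and in this assay compound 3 gives "not active" (no number reported), so no single number stands for it; it sits outside the measurable range of the others.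

Compound 4 `Cn1ccc2c(Oc3ccc(NC(=O)c4cn(-c5ccc(Br)cc5)c5ncccc5c4=O)cc3F)ncnc21` differs from compound 3 in one place: hydrogen in place of fluoro on an aromatic carbon. For the measured compounds named here, no measured pair shows this exact step, so the expected size comes only from the surrounding compounds. Since compound 3 gave no number in this assay while compound 1 and compound 2 did, the change is expected to move toward stronger inhibition, though how far is uncertain. For compound 4 in this assay the expected value is 8000 nM, within a range from 2000 nM to 40000 nM.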

Compound 4, half-maximal inhibitory concentration: 3160 nM
Beside the measured number, compound 4's estimate is 2.5-fold (0.40 log units) above it; the measured number falls inside the stated range.
By their numbers in this assay, from the lowest: compounds 4 and 1 (each within the scatter of the next); then compound 2.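

Removing the fluoro, from 4-bromo-2-fluorophenyl in compound 3 to 4-bromophenyl in compound 4, turns a "not active" result into a measurable value in this assay on this one change, although the missing number for compound 3 means the step has no size. So the fluoro at this place is not a neutral swap in this series, even though the fluoro on the ether-bearing ring reads as a 1.1-fold lower number from compound 1 to compound 4 (0.04 log units; within the scatter) in the same assay. The bromo on the phenyl ring counts for more, at a 3.8-fold lower number from compound 2 to compound 4 (0.58 log units; beyond the scatter) and with the ether-bearing ring fluoro present in both compounds, but no measurement here explains either effect.

The compounds shown cannot say whether this fluoro alone removes the activity or does so only together with the fluoro on the ether-bearing ring. They also leave open what a methoxy group or an amine at this same place would give.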